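The compounds below may be only part of what the source reports. "The series", "measured", "known", "first", "only" and "open" are said of these compounds alone.

Three compounds built on a shared core were tested in a functional assay on PC-3 cells (Homo sapiens) for cytotoxicity, read by MTT assay, with a stated time of 48 h; a higher number here means a weaker inhibitor, a lower number a stronger inhibitor. Compound 1 `CC1=NN(C(=O)CCl)C(c2cc(Br)ccc2O)C1` gives 8890 nM in this assay. Compound 2 `CC1=NN(S(=O)(=O)c2ccc([N+](=O)[O-])cc2)C(c2cc(Cl)ccc2O)C1` gives 44200 nM in this assay. Compound 3 `CC(=O)Oc1ccccc1C1CC(C)=NN1C(=O)CN(C(C)C)C(C)C` gives 24500 nM in this assay. Among these three numbers compound 3 stands second highest. Its value and that of compound 2 lie within the scatter of each other, so no order between them can be read, whereas compound 1 shows a lower number than compound 3, and that gap lies beyond the scatter.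

Compound 4 `CC(=O)Oc1ccccc1C1CC(C)=NN1C(=O)CN1CCC(C(C)=O)CC1` has not yet been measured. It differs from compound 3 in a single place: 4-acetylpiperidin-1-yl in place of diisopropylamino on a saturated chain carbon bound to a carbonyl carbon. Everything else in the structure stays the same. Going by the values given here, no pair of measured compounds differing in one place is available, so nothing among the measured compounds shows how an exchange of this kind on that chain carbon moves the number. The account therefore expects the step of a 1.1-fold lower number from compound 3 to compound 4 (0.05 log units; within the scatter) to be small, with no direction that reaches beyond the scatter. On that footing compound 4 is estimated to give 22000 nM in this assay, with a range from 7000 nM to 70000 nM.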

Compound 4, half-maximal inhibitory concentration: 6800 nM
For compound 4 the middle estimate is 3.2-fold (0.51 log units) above the measured one; the measured number lies below the stated range.
By their numbers in this assay, from the lowest: compounds 4 and 1 (each within the scatter of the next); then compounds 3 and 2 (each within the scatter of the next).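

In this assay, the exchange of diisopropylamino for 4-acetylpiperidin-1-yl on a saturated chain carbon bound to a carbonyl carbon gives a 3.6-fold lower number from compound 3 to compound 4 (0.56 log units; beyond the scatter), a modest step that lies beyond the scatter. Going by these compounds alone, this is the first evidence from a pair differing in one place that the group at this position can move the number, which the earlier compounds could not show. The exchange brings in a six-membered non-aromatic ring, an oxygen atom and a double bond outside aromatic rings all at once, and nothing measured here gives a reason for the step or assigns it to any one of these features.

The compounds shown leave open whether the ring alone carries the step or whether the acetyl group is needed, a question that plain piperidin-1-yl and morpholin-4-yl at the same place would address. They also leave open whether the same exchange moves the number in the same direction when the acetyl ester on the core is replaced by a free hydroxyl group, the form carried by compound 1.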